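The source may report more compounds than this note shows. Statements on the series, on what has been measured and on what is new or still open speak of the compounds shown alone.

Compound 1 `Cc1cccc(C#Cc2nc3c(s2)C(=O)NCC3)c1`: in an assay on HEK293 cells for positive allosteric modulation of metabotropic glutamate receptor 5 (Homo sapiens), read by FLIPR, with a stated time of 1 h (on this read-out lower numbers stand for an effect already at smaller amounts and higher numbers for an effect only at larger amounts of compound), compound 1 gives a limit of > 10000 nM, not a number.
Compound 2 `O=C(C1CC12CCC2)N1CCc2nc(C#Cc3ccccc3)sc2C1`: in this assay compound 2 gives 3.9 nM.
Compound 3 `O=C(C1CC(F)(F)C1)N1CCc2nc(C#Cc3cccc(F)c3)sc2C1`: in this assay compound 3 gives 2.5 nM.

Within the data shown here, only two compounds give numbers at all; compound 1 shows just the assay limit, (the limit of > 10000 nM in this assay, at which 1 of the 3 values shown sits). Among the two numbers, compound 2 sits at one end, yet compound 3 lies so close that the two cannot be told apart within the usual scatter. Compound 4 `Cc1nc(C(=O)N2CCc3nc(C#Cc4ccccc4)sc3C2)cs1` has not been measured in this assay. It differs from compound 2 in a single place: a group of 6 heavy atoms (4 carbon, 1 nitrogen, 1 sulfur; one five-membered aromatic ring with 2 hetero atoms) in place of a group of 6 heavy atoms (6 carbon; one three-membered non-aromatic ring of carbon only, one four-membered non-aromatic ring of carbon only), on a carbonyl carbon The amide carbonyl and the ring nitrogen it sits on are kept; only the group attached to that carbonyl carbon is swapped, from the saturated spiro pair of small carbon rings to the 2-methyl-1,3-thiazol-4-yl ring. Among the measured compounds shown here, no measured pair shows this kind of swap, so the expectation rests on compound 2 alone, whose value of 3.9 nM serves as the starting point. A step of a 2.1-fold higher number from compound 2 to compound 4 (0.31 log units; beyond the scatter) is expected, a mild rise in the number that may fall within the scatter or a little beyond it. For compound 4 the estimate in this assay is 8 nM, in a range from 2 nM to 40 nM.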

Compound 4, half-maximal effective concentration: 220 nM
The estimate for compound 4 lay 28-fold (1.44 log units) below the measured number; the measured number lies above the stated range.
By their numbers in this assay, from the lowest: compounds 3 and 2 (each within the scatter of the next); then compound 4. At a limit, above all of these: compound 1.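

In this assay, the group on the carbonyl carbon proves to matter a great deal: keeping the rest of compound 2 and placing 2-methyl-1,3-thiazol-4-yl there gives a 56-fold higher number from compound 2 to compound 4 (1.75 log units; beyond the scatter). This is the first comparison shown of two compounds that differ only at this place, and the step lies well beyond the scatter. The two groups have the same number of heavy atoms and no net charge, so these counts alone do not keep the number low at this position.

The compounds shown do not tell which difference between the two groups accounts for the step, whether the aromatic ring, its hetero atoms or its methyl group. On these data alone, it also remains open where a thiazole ring without the methyl group or a pyridine ring would fall at this carbonyl carbon.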